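Acetyl to methyl on the phenolic oxygen of compound 3

A few compounds are considered here, and "the series" means these few. Any claim that something is new, unique, unknown or untested is made for them only; others in the source may bear on it.

Measured so far:
Compound 1 `CCOC(=O)c1c(C)coc1-c1ccc2c(CC)cccc2c1OC`: in a functional assay on MDA-MB-231 cells (Homo sapiens) for cytotoxicity, read by MTT assay, with a stated time of 72 h (on this read-out lower numbers stand for an effect already at smaller amounts and higher numbers for an effect only at larger amounts of compound), compound 1 gives 3.9 ug/mL.
Compound 2 `CCc1cccc2c(OC)c(-c3occ(C)c3CO)ccc12`: in this assay compound 2 reaches only the limit of the assay, > 10 ug/mL.
Compound 3 `CCc1cccc2c(OC(C)=O)c(-c3occ(C)c3COC(C)=O)ccc12`: in this assay compound 3 likewise reaches only the limit of the assay, > 10 ug/mL.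

Compound 3 therefore stands at the top of what this assay can report, one of the two compounds sitting at that limit (the limit of > 10 ug/mL in this assay, at which 2 of the 3 values shown sit). Among the compounds with values here, only one step between measured compounds is known: an at least 2.5-fold higher number from compound 1 to compound 2 (0.40 log units; beyond the scatter), which goes toward a higher number and is at least modest. Compound 4 `CCc1cccc2c(OC)c(-c3occ(C)c3COC(C)=O)ccc12` differs from compound 3 in a single place: methyl in place of acetyl on an oxygen on an aromatic ring. Within the data shown here, no measured step touches that place, since the step from compound 1 to compound 2 concerns a different group, so no direct guide exists for the size of this change. What can be noted is that compound 4 shares its methoxy with compound 2, and in this assay compound 2 gives > 10 ug/mL, a limit. On that basis compound 4 is expected to remain near the limit as well, with an estimated step that the limit leaves unreadable from compound 3 to compound 4. The estimate for compound 4 in this assay is 15 ug/mL, ranging from 5 ug/mL to 45 ug/mL.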

Compound 4, concentration for half-maximal effect: 3.5 ug/mL
Compound 4: the middle estimate sits 4.3-fold (0.63 log units) above what was measured, and the stated range ends above it.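

In this assay, the oxygen on the aromatic ring proves to be a sensitive place: with the acetoxymethyl group unchanged, going from acetoxy to methoxy there gives an at least 2.8-fold lower number from compound 3 to compound 4 (0.45 log units; beyond the scatter). The oxygen on a saturated carbon is sensitive as well, since acetyl in place of hydrogen there gives an at least 2.8-fold lower number from compound 2 to compound 4 (0.45 log units; beyond the scatter), so a change at either of two separate places can be enough to separate compound 4 from a compound at the limit. On the aromatic carbon, acetoxymethyl in place of ethoxycarbonyl gives a 1.1-fold lower number from compound 1 to compound 4 (0.05 log units; within the scatter), so these two groups cannot be told apart here, although hydroxymethyl and ethoxycarbonyl could.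

As far as these compounds go, the real size of the first two steps stays open, as compound 2 and compound 3 give only limits, not numbers: the limit of > 10 ug/mL in this assay, at which 2 of the 4 values shown sit. Also open is how far each place tolerates other groups, such as a free hydroxyl or a longer ethoxy chain on the oxygen on the aromatic ring, or an amide or a carboxylic acid in place of the acetoxymethyl group on the aromatic carbon.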